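Working notes: aryl swap on the sulfonyl sulfur of compound 2

The compounds below may be only part of what the source reports. "The series", "measured", "known", "first", "only" and "open" are said of these compounds alone.

Two compounds of the shared core have numbers in a functional assay on MCF7 cells (Homo sapiens) for antiproliferative activity, read by MTT assay, with a stated time of 48 h (on this read-out higher numbers stand for weaker inhibition and lower numbers for stronger inhibition), so far. Compound 1 `O=C(Nc1cccc(/C=C/C(=O)c2nc3ccccc3[nH]2)c1)c1cccc(Cl)c1` gives 7840 nM. Within the data shown here, compound 2 `O=C(/C=C/c1cccc(NS(=O)(=O)c2ccc(Cl)cc2)c1)c1nc2ccccc2[nH]1` gives 3820 nM and so holds the lowest of the two numbers; the only measured step, a 2.1-fold lower number from compound 1 to compound 2 (0.31 log units; beyond the scatter), is modest and goes with a (4-chlorophenyl)sulfonyl in place of a (3-chlorophenyl)carbonyl on a nitrogen on an aromatic ring.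

Compound 3 `Cc1ccc(S(=O)(=O)Nc2cccc(/C=C/C(=O)c3nc4ccccc4[nH]3)c2)cc1C` keeps the sulfonyl link and differs from compound 2 in a single place: 3,4-dimethylphenyl in place of 4-chlorophenyl on a sulfonyl sulfur whose other neighbour is the sulfonamide nitrogen. Among the measured compounds shown here, no measured step touches the aryl group on the sulfonyl sulfur; the step from compound 1 to compound 2 alters the link itself and gives no guide to a change of the aryl group alone. With nothing to rest on, the expected step is a 1.1-fold lower number from compound 2 to compound 3 (0.03 log units; within the scatter), nothing beyond the scatter in either direction. For compound 3 the estimate in this assay is 3600 nM, with a range from 1400 nM to 9000 nM.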

Compound 3, half-maximal inhibitory concentration: 5860 nM
Beside the measured number, compound 3's estimate is 1.6-fold (0.21 log units) below it, and the stated range covers the measured number.
By their numbers in this assay, from the lowest: compounds 2, 3 and 1 (each within the scatter of the next, the first and the last beyond it).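

In this assay, the aryl group on a sulfonyl sulfur whose other neighbour is the sulfonamide nitrogen can now be read on its own, with the link held constant: 3,4-dimethylphenyl in place of 4-chlorophenyl gives a 1.5-fold higher number from compound 2 to compound 3 (0.19 log units; within the scatter). The earlier step altered the link itself, whereas this one shows that, for this single pair, an aryl ring bearing chlorine and one bearing two methyl groups cannot be told apart in this read-out. The change replaces 7 heavy atoms with 8 and keeps one six-membered aromatic ring of carbon only, but nothing at hand says what lies behind the result.

As far as these compounds go, one exchange between two substituted phenyl groups does not define the scope of this position, so it remains open whether a phenyl carrying an amine or a carboxylic acid, or a plain methyl on the sulfonyl sulfur in place of the aryl ring, would give a step beyond the scatter. A 4-methylphenyl group would also be informative, as it would separate the exchange of chlorine for methyl from the addition of the second methyl.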